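A few compounds are considered here, and "the series" means these few. Any claim that something is new, unique, unknown or untested is made for them only; others in the source may bear on it.

Measured compounds:
- compound 1 `COC(=O)[C@@]1(C)CCC=C2[C@@H]1CC[C@@H](C)[C@]2(C)Cc1c[nH]c2ccccc12`: 7300 nM in a functional assay on SW1573 cells (Homo sapiens) for inhibition, read by sulforhodamine B assay, with a stated time of 48 h; on this read-out lower numbers stand for stronger inhibition of growth and higher numbers for weaker inhibition of growth
- compound 2 `COC(=O)[C@@]1(C)CCC=C2[C@@H]1CC[C@@H](C)[C@]2(C)Cc1c[nH]c2ccc(C)cc12`: 15000 nM in this assay
- compound 3 `COC(=O)[C@@]1(C)CC[C@@H]2C3=C1CC[C@@H](C)[C@]3(C)C[C@@H]1c3ccccc3N[C@H]21`: 30000 nM in this assay

Compound 1 and compound 2 differ in one place, (methyl in place of hydrogen on an aromatic carbon). This change gave a 2.1-fold higher number from compound 1 to compound 2 (0.31 log units; beyond the scatter). Compound 3 has the same atoms as compound 1 joined differently; the difference between the two cores is not broken down here, and the values of compound 1 and compound 3 given above are all that can be said of the pair. Compound 2 and compound 3 lie within the scatter of each other.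

Compound 4 `COC(=O)[C@@]1(C)CC[C@@H]2C3=C1CC[C@@H](C)[C@]3(C)C[C@@H]1c3cc(C)ccc3N[C@H]21` is not yet measured. Relative to compound 3 it carries methyl in place of hydrogen on an aromatic carbon. The surroundings are not identical to the first pair: in compound 2 the ring bearing the methyl is part of a fused or bridged system of two rings, in compound 4 part of a fused or bridged system of five rings, so this is the same kind of change rather than the same change. The expected step in this assay is a 2.0-fold higher number from compound 3 to compound 4 (0.30 log units; within the scatter), set beside a 2.1-fold higher number from compound 1 to compound 2 (0.31 log units; beyond the scatter), and it rests on that single earlier step only. On that basis compound 4 is estimated at 60000 nM, between 30000 nM and 120000 nM.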

Compound 4, concentration for 50% growth inhibition: 23000 nM
For compound 4 the middle estimate is 2.6-fold (0.42 log units) above the measured one, and the stated range ends above it.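

In this assay, methyl in place of hydrogen on an aromatic carbon gives a 1.3-fold lower number from compound 3 to compound 4 (0.12 log units; within the scatter), so on the core of compound 3 this step cannot be told apart from the scatter. Within the data shown here, the step seen on the core of compound 1 therefore does not carry over unchanged to the core of compound 3, and the two steps differ by more than the scatter allows: the same change on two cores in this assay, a 2.1-fold higher number (0.31 log units; beyond the scatter) from compound 1 to compound 2 and a 1.3-fold lower number (0.12 log units; within the scatter) from compound 3 to compound 4, 2.7-fold (0.43 log units) apart, beyond the scatter of two such steps With only one pair on each core, this does not show why the two steps differ, nor whether the difference would hold for another group or another ring position.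

The compounds shown leave open whether a group other than methyl, such as chloro or methoxy, would give matching steps on the two cores. Also open, going by these compounds, is whether a carboxylic acid or an amide in place of the methyl ester would shift the two cores alike.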